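Side-chain variation on the shared amide ester series

A few compounds are considered here, and "the series" means these few. Any claim that something is new, unique, unknown or untested is made for them only; others in the source may bear on it.

Compound 1 `O=C(CN(c1nc(Cl)nc2[nH]cnc12)C1CC1)N[C@@H](CO)C(=O)OCc1ccccc1`, compound 2 `N=C(N)NCCC[C@H](NC(=O)CN(c1nc(Cl)nc2[nH]cnc12)C1CC1)C(=O)OCc1ccccc1` and compound 3 `O=C(CN(c1nc(Cl)nc2[nH]cnc12)C1CC1)N[C@@H](CCC(=O)OCc1ccccc1)C(=O)OCc1ccccc1` share one core and differ only in the side chain. In a functional assay on the whole organism (Tail, strain ICR) with Mus musculus as the target, in the tail flick test, with a stated time of 90 min, at a dose of 25 umol/kg by the oral route (on this read-out higher numbers stand for a stronger effect at the one dose given and lower numbers for a weaker effect), compound 1 gives 34.5%, compound 2 gives 30.4% and compound 3 gives 50%. Compound 3 stands highest of the three: the gaps are a number 15.5 percentage points higher from compound 1 to compound 3 (beyond the scatter) and a number 19.6 percentage points higher from compound 2 to compound 3 (beyond the scatter), both beyond the scatter, while a number 4.1 percentage points lower from compound 1 to compound 2 (within the scatter) lies within it. Compound 4 `NCCCC[C@H](NC(=O)CN(c1nc(Cl)nc2[nH]cnc12)C1CC1)C(=O)OCc1ccccc1` carries 2-aminoethyl in place of benzyloxycarbonyl on a saturated chain carbon, three bonds along the chain from an amide-type nitrogen and a carbonyl carbon. The step that bears on it most is that from compound 2 to compound 3, where benzyloxycarbonyl entered; compound 4 reverses that and brings in 2-aminoethyl, so for compound 4 a modest fall in this assay is expected, a number 18 percentage points lower from compound 3 to compound 4 (beyond the scatter). Compound 4 is estimated at 32%, between 18% and 46%.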

Compound 4, a percentage reported as activity, at one dose (the size of the read-out at that dose, not a potency): 35.3%
Compound 4: middle estimate off by 3.3 percentage points, on the low side; the measured number falls inside the stated range.
By their numbers in this assay, from the lowest: compounds 2, 1 and 4 (each within the scatter of the next); then compound 3.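

In this assay, replacing 2-(benzyloxycarbonyl)ethyl with 4-aminobutyl at this place gives a number 14.7 percentage points lower from compound 3 to compound 4 (beyond the scatter), whereas a number 4.9 percentage points higher from compound 2 to compound 4 (within the scatter) and a number 0.8 percentage points higher from compound 1 to compound 4 (within the scatter). Among these four side chains, only that of compound 3 stands apart, and the amine chain of compound 4 cannot be told from the side chains of compound 1 and compound 2. No available data explain this difference.

From the compounds shown here alone, it remains open whether the whole benzyloxycarbonyl group or only its aromatic ring goes with the higher number of compound 3. A carboxylic acid or a methyl ester on the same chain would help separate these two readings.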